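Thioether amides on SMMC-7721 cells: working notes toward compound 3

The source may hold more compounds than are shown below. What is called first, only, known or untested is meant among the compounds shown, and "the series" means these compounds.

compound 1 `COc1ccc(SCc2ccc(/C=C/C(=O)Nc3ccccc3N)cc2)cc1OC` — 44.6%
compound 2 `Nc1ccccc1NC(=O)c1ccc(CSc2ccc(Cl)cc2)cc1` — 16.5%

In a functional assay on SMMC-7721 cells (Homo sapiens) for inhibition, read by CCK-8 assay, with a stated time of 72 h, tested at 8 uM (on this read-out lower numbers stand for less inhibition of growth and higher numbers for more inhibition of growth at the one concentration tested), compound 1 gives 44.6%, the highest of the two numbers. Compound 2 gives 16.5%, a number lower by a gap beyond the scatter. Among the compounds with values here, compound 2 differs from compound 1 in more than one place, so the two values show only where each stands; no single-point step is drawn between them.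

Compound 3 `Nc1ccccc1NC(=O)/C=C/c1ccc(CSCCc2ccccc2)cc1` differs from compound 1 in one place: phenethyl in place of 3,4-dimethoxyphenyl on a sulfur. Within the data shown here, no measured pair covers this change, so its size is not known from the data. The core of compound 1 is kept, and the expectation in this assay is a small step downward, at the edge of the scatter, as a number 6.6 percentage points lower from compound 1 to compound 3 (within the scatter). Compound 3 is therefore expected to give 38%, with a range from 20% to 55%.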

Compound 3, percent growth inhibition at one concentration: 15.8%
For compound 3 the middle estimate is 22.2 percentage points above the measured one; measured number outside the range, below it.
By their numbers in this assay, from the lowest: compounds 3 and 2 (each within the scatter of the next); then compound 1.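

In this assay, within the data shown here, the group on the sulfur proves able to move the value on its own: with the core of compound 1 kept, phenethyl in place of 3,4-dimethoxyphenyl gives a number 28.8 percentage points lower from compound 1 to compound 3 (beyond the scatter) and this is the first single-point step. The change therefore shows that this position is not indifferent to substitution, and that keeping the core does not by itself hold the value. It swaps several features at once, as the leaving group carries two hydrogen-bond acceptors and the entering group none, and no measurement here bears on which of them matters.

Still open, on these data alone, is whether the methoxy groups or the saturated chain accounts for the step. A plain phenyl or a 4-methoxyphenyl on the sulfur would separate the two, and a benzyl would test a shorter chain.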